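The compounds below may be only part of what the source reports. "The series", "measured", "known", "first", "only" and "open" are said of these compounds alone.

Compound 1, `O=C1NCCN(c2cccc(O)c2)N1`: in an assay on RBL-1 cells for inhibition of Polyunsaturated fatty acid 5-lipoxygenase (Rattus norvegicus) (a lower number here means a stronger inhibitor, a higher number a weaker inhibitor), compound 1 gives 32000 nM.
Compound 2, `CCCCC1CN(c2ccccc2)NC(=O)N1`: in this assay compound 2 gives 1500 nM.
Compound 3, `O=C1NCCN(c2ccccn2)N1`: in this assay compound 3 gives 26000 nM.

Of the three numbers, compound 3 holds the second highest. Its nearest neighbour is compound 1, whose number lies within the usual scatter of this assay, so the two cannot be told apart on these data. Compound 2 stands farthest away, with a number beyond the scatter below that of compound 3. Compound 2 differs from compound 3 in more than one place, so this gap says nothing about any single structural change.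

Compound 4, `O=C1NCCN(c2cccc(Br)n2)N1`, has not yet been measured. It differs from compound 3 in one place only: bromo in place of hydrogen on an aromatic carbon, in words, bromo in place of hydrogen on an aromatic carbon. Going by the values given here, no pair of measured compounds differs by a change of this kind, so there is no measured step to lean on. In this assay the expected step is a 1.7-fold lower number from compound 3 to compound 4 (0.24 log units; within the scatter), which is to say a small shift whose direction is uncertain and which may well stay within the scatter. For compound 4 the estimate is 15000 nM, with a range from 4000 nM to 50000 nM.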

Compound 4, half-maximal inhibitory concentration: 3500 nM
For compound 4 the middle estimate is 4.3-fold (0.63 log units) above the measured one; measured number outside the range, below it.
By their numbers in this assay, from the lowest: compound 2; then compound 4; then compounds 3 and 1 (each within the scatter of the next).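

In this assay, going by these compounds alone, bromo in place of hydrogen on an aromatic carbon next to the ring nitrogen brings a 7.4-fold lower number from compound 3 to compound 4 (0.87 log units; beyond the scatter), the first change in a single place that can be read in this set. The step is modest but beyond the scatter, so this carbon of the six-membered aromatic ring is not indifferent to what it carries, and here a bromo goes with a stronger inhibitor rather than a weaker one. Nothing available here shows what lies behind this gain, so the step stands as an observation without an explanation.

With a single substituent at this carbon, the compounds shown cannot tell whether the gain is particular to bromo or would also appear with another group there, such as chloro, methyl, methoxy or an amine. They also leave open whether a bromo on another carbon of the same ring would shift the number as much, and whether this gain would persist if a longer chain were added to the core.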